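Chloro in place of hydrogen on the phenyl ring

The source may report more compounds than this note shows. Statements on the series, on what has been measured and on what is new or still open speak of the compounds shown alone.

Four analogues share one core. Compound 1 `Cc1ccccc1Nc1nc(C)c(C(=O)/C=C/c2ccc(Cl)cc2)s1`, compound 2 `Cc1ccccc1Nc1nc(C)c(C(=O)/C=C/c2ccccc2)s1` and compound 3 `Cc1nc(Nc2ccccc2)sc1C(=O)/C=C/c1ccccc1` are measured in a functional assay on BGC-823 cells (Homo sapiens) for cytotoxicity, read by MTT assay; a higher number here means a weaker inhibitor, a lower number a stronger inhibitor; compound 4 `Cc1nc(Nc2ccccc2)sc1C(=O)/C=C/c1ccccc1Cl` is not. In this assay compound 1 returns only a limit, > 25000 nM. Compound 2 likewise returns only a limit, > 25000 nM. Among the compounds with values here, compound 3 gives 19500 nM, the single number in the set. Compound 3 differs from compound 2 by hydrogen in place of methyl on an aromatic carbon, a step of an at least 1.2-fold lower number from compound 2 to compound 3 (0.10 log units; that floor lies within the scatter). The change from compound 2 to compound 1, (chloro in place of hydrogen on an aromatic carbon), gives a step that the two limits leave unreadable from compound 2 to compound 1, its size left open by the limit of > 25000 nM in this assay, at which 2 of the 3 values shown sit. Compound 4 carries the same kind of change on compound 3, (chloro in place of hydrogen on an aromatic carbon); the places differ, para to a large group against ortho to a large group. The expected step is a 1.3-fold lower number from compound 3 to compound 4 (0.11 log units; within the scatter), resting on compound 3 at 19500 nM and on the unread a step that the two limits leave unreadable from compound 2 to compound 1. Compound 4 is estimated at 15000 nM, between 5000 nM and 40000 nM.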

Compound 4, half-maximal inhibitory concentration: 22800 nM
For compound 4 the middle estimate is 1.5-fold (0.18 log units) below the measured one, within the range that was stated.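

In this assay, phenyl to 2-chlorophenyl on the core of compound 3 gives a 1.2-fold higher number from compound 3 to compound 4 (0.07 log units; within the scatter), so this change shows no readable effect on that core. Compound 1 and compound 2 each return only a limit, so the same change on the core of compound 2 cannot be read: the limit of > 25000 nM in this assay, at which 2 of the 4 values shown sit. Carrying the change from one core to the other is thus neither supported nor contradicted, and the chloro also sits at different places on the ring in compound 1 and compound 4.

The compounds shown leave open whether any substituent on this ring moves the number beyond the scatter. An amine or a carboxylic acid on that ring remains an open case, as does chloro on the core of compound 3 at the place it holds in compound 1.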